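Exchanging One Ring Group on Compound 2

A few compounds are considered here, and "the series" means these few. Any claim that something is new, unique, unknown or untested is made for them only; others in the source may bear on it.

In a functional assay (muscle tissue) with Rattus norvegicus as the target (a higher number here means that more compound is needed for the effect, a lower number that less compound is needed), compound 1 (`CO/C(O)=C1/C(C)=NC(C)=C([N+](=O)[O-])C1c1ccccc1OCc1no[n+]([O-])c1C#N`) gives 5200 nM while compound 2 (`CO/C(O)=C1/C(C)=NC(C)=C([N+](=O)[O-])C1c1ccccc1OCc1no[n+]([O-])c1C`) gives 1200 nM and so holds the lower of the two numbers. Compound 3 (`CO/C(O)=C1/C(C)=NC(C)=C([N+](=O)[O-])C1c1ccccc1OCc1nonc1C#N`) keeps the core of compound 2 but differs on a saturated chain carbon bound to an oxygen on an aromatic ring, where 4-cyano-1,2,5-oxadiazol-3-yl enters (a group of 7 heavy atoms (3 carbon, 3 nitrogen, 1 oxygen; one five-membered aromatic ring with 3 hetero atoms) in place of a group of 7 heavy atoms (3 carbon, 2 nitrogen, 2 oxygen; one five-membered aromatic ring with 3 hetero atoms), on a saturated chain carbon bound to an oxygen on an aromatic ring) in place of the group found there. Among the compounds with values here, the only measured step that bears on this is a 4.3-fold lower number from compound 1 to compound 2 (0.64 log units; beyond the scatter) for methyl in place of cyano on an aromatic carbon. The entering group carries a cyano, so that step, read in reverse, points towards a higher number. Within the data shown here, no measured step covers the remainder of the exchange, which leaves the size uncertain. In this assay the expected change, of similar modest size or slightly larger, is an estimated 5.0-fold higher number from compound 2 to compound 3 (0.70 log units; beyond the scatter) for this exchange. Compound 3 is therefore expected at about 6000 nM with an estimated range of 1800 nM to 20000 nM as the likely span of the measurement.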

Compound 3, half-maximal effective concentration: 1500 nM
Compound 3: the middle estimate sits 4.0-fold (0.60 log units) above what was measured, and the stated range ends above it.
By their numbers in this assay, from the lowest: compounds 2 and 3 (each within the scatter of the next); then compound 1.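

In this assay, placing 4-cyano-1,2,5-oxadiazol-3-yl on the saturated chain carbon bound to an oxygen on an aromatic ring gives a 1.3-fold higher number from compound 2 to compound 3 (0.10 log units; within the scatter) and so leaves compounds 2 and 3 indistinguishable, although the entering group carries a nitrile. Compound 1 also carries a nitrile, and its group differs from the entering one by a single oxygen in the count, yet the exchange gives a 3.5-fold lower number from compound 1 to compound 3 (0.54 log units; beyond the scatter) and thus shows that a nitrile at this position does not by itself go with the higher number, with compound 3 standing against that reading. Nothing at hand explains why these two nitrile-bearing groups differ.

The compounds shown leave open whether a methyl, an amine or a carboxylic acid in place of the nitrile of 4-cyano-1,2,5-oxadiazol-3-yl would also stay level with compound 2. They also leave open whether a longer chain between that group and the oxygen on the aromatic ring would keep the number where compounds 2 and 3 stand.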